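The source may hold more compounds than are shown below. What is called first, only, known or untested is meant among the compounds shown, and "the series" means these compounds.

Measured so far:
compound 1, `COc1ccc(-c2oc3ccc(NC(C)=O)cc3c(=O)c2O)cc1`, 9000 nM
compound 2, `COc1ccc(-c2oc3ccc(N)cc3c(=O)c2O)cc1`, 29000 nM
compound 3, `COc1c(-c2ccccc2)oc2ccc(NC(C)=O)cc2c1=O`, > 125000 nM

All three numbers come from an ADME assay on THP-1 cells (Homo sapiens) for cytotoxicity, read by flow cytometry and propidium iodide staining, with a stated time of 72 h; a lower number here means a stronger inhibitor, a higher number a weaker inhibitor. Compound 1 gives 9000 nM and compound 2 gives 29000 nM. Between them stands one change, (hydrogen in place of acetyl on a nitrogen on an aromatic ring), which gives a 3.2-fold higher number from compound 1 to compound 2 (0.51 log units; beyond the scatter). For compound 3 the value of > 125000 nM is a limit of the assay and not a number; this is the limit of > 125000 nM in this assay, at which 1 of the 3 values shown sits. How the core of compound 3 differs from the core of compound 1 is not broken down here.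

Compound 4, `COc1c(-c2ccccc2)oc2ccc(N)cc2c1=O`, remains to be measured in this assay. It is related to compound 3 by hydrogen in place of acetyl on a nitrogen on an aromatic ring, the same change as that from compound 1 to compound 2, made on the core of compound 3; the place of the change is described in the same words in both pairs.

In the measured pair the change moved the number upward, that is toward a weaker effect, and compound 3 already sits at the limit. On that basis the step from compound 3 to compound 4 is expected to be a step that the limit leaves unreadable from compound 3 to compound 4, in the same direction as a 3.2-fold higher number from compound 1 to compound 2 (0.51 log units; beyond the scatter), and most likely to leave compound 4 at the limit as well. Compound 4 is therefore estimated at 300000 nM, within a range from 125000 nM to 1200000 nM.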

Compound 4, half-maximal inhibitory concentration: 74000 nM
Compound 4: the middle estimate sits 4.1-fold (0.61 log units) above what was measured; the whole stated range lies above it.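

In this assay, the change from acetamido to amino gives an at least 1.6-fold lower number from compound 3 to compound 4 (0.22 log units; that floor lies within the scatter), so this step read alone stays small at its floor. Set beside the earlier step, the change does not carry over from the core of compound 1 to the core of compound 3 with one size or direction: the same change on two cores in this assay, a 3.2-fold higher number (0.51 log units; beyond the scatter) from compound 1 to compound 2 and an at least 1.6-fold lower number (0.22 log units; that floor lies within the scatter) from compound 3 to compound 4, at least 5.4-fold (0.73 log units) apart, beyond the scatter of two such steps

The value of compound 3, > 125000 nM, is a limit of the assay and not a number, so only a floor of this step is known, and two pairs on two cores give neither a cause for the gap nor a rule for any further core.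

The compounds shown do not separate which feature of the two cores goes with the gap between the steps. Also open, as far as these compounds go, is how either core responds when the nitrogen carries a group other than acetyl or hydrogen, such as a propanoyl or a methanesulfonyl group.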